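Opening the amide ring: from compound 1 to compound 4

This account rests on a few compounds, and the source may have more. Where it says the series, first, only, none or still open, it means among the compounds named here.

Compound 1 `CSc1ccccc1N1CCN(CCCCCC(=O)N2CCc3ccccc3C2)CC1` is the weakest of three compounds measured in an assay on HEK293 cells for displacement of a labelled ligand from 5-hydroxytryptamine receptor 7 (Rattus norvegicus) (a lower number here means a stronger inhibitor, a higher number a weaker inhibitor), where compound 1 gives 32.9 nM. Its two neighbours change only the group on the aromatic carbon: compound 2 `O=C(CCCCCN1CCN(c2ccccc2-c2ccccc2)CC1)N1CCc2ccccc2C1` gives 3.81 nM, and compound 3 `CC(C)c1ccccc1N1CCN(CCCCCC(=O)N2CCc3ccccc3C2)CC1` gives 6 nM. The step of an 8.6-fold lower number from compound 1 to compound 2 (0.94 log units; beyond the scatter) and the step of a 5.5-fold lower number from compound 1 to compound 3 (0.74 log units; beyond the scatter) both lower the number, while the step of a 1.6-fold higher number from compound 2 to compound 3 (0.20 log units; within the scatter) stays within the scatter.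

Compound 4 `CSc1ccccc1N1CCN(CCCCCC(=O)NCc2ccccc2)CC1` alters a different part of the molecule: benzylamino in place of 1,2,3,4-tetrahydroisoquinolin-2-yl on a carbonyl carbon. Among the compounds with values here, none of the measured steps touches this carbonyl carbon, so none of them bears on the change, and there is no direct guide to its size or direction. The group that leaves is a ring fused to the amide nitrogen; the group that enters brings a hydrogen-bond donor and two fewer heavy atoms. Within the data shown here, with no comparable step to rest on, the expectation for compound 4 in this assay is a modest rise in the number, a 1.8-fold higher number from compound 1 to compound 4 (0.26 log units; within the scatter), held with wide uncertainty. The estimate for compound 4 is therefore 60 nM, with a range from 15 nM to 250 nM.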

Compound 4, inhibition constant: 22 nM
For compound 4 the middle estimate is 2.7-fold (0.44 log units) above the measured one; measured number inside the range.
By their numbers in this assay, from the lowest: compounds 2 and 3 (each within the scatter of the next); then compounds 4 and 1 (each within the scatter of the next).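

In this assay, replacing the fused 1,2,3,4-tetrahydroisoquinolin-2-yl group on the carbonyl carbon with the open benzylamino group gives a 1.5-fold lower number from compound 1 to compound 4 (0.17 log units; within the scatter) and so leaves the number within the scatter, even though the incoming group has a hydrogen-bond donor that the outgoing one lacks and fewer heavy atoms. Within the data shown here, the earlier steps all changed the group on the aromatic carbon, and some went beyond the scatter, such as an 8.6-fold lower number from compound 1 to compound 2 (0.94 log units; beyond the scatter), so this pair is the first view of the other end of the molecule, where the ring can be opened without a change that can be told from the scatter. Nothing in the data given accounts for this result.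

The compounds shown leave open whether the amide hydrogen itself matters, which an N-methylbenzylamino group on the same carbonyl carbon could help to test, and whether a longer link such as a 2-phenylethylamino group behaves like benzylamino. They also do not show whether benzylamino would give a similar result alongside the isopropyl or phenyl group on the aromatic carbon.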